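From a four-membered ring to a three-membered ring

A few compounds are considered here, and "the series" means these few. Any claim that something is new, unique, unknown or untested is made for them only; others in the source may bear on it.

In a physicochemical assay for solubility, with a stated time of 24 h, tested at 30 mg/mL (on this read-out lower numbers stand for lower solubility and higher numbers for higher solubility), compound 1 (`Cc1cc(COc2ccc(S(=O)(=O)NCCC(=O)NO)cc2)c2ccccc2n1`) gives 4100000 nM and compound 2 (`Cc1cc(COc2ccc(S(=O)(=O)NC3(CC(=O)NO)COC3)cc2)c2ccccc2n1`) gives 200000 nM as the lower of the two numbers. Compound 3 (`Cc1cc(COc2ccc(S(=O)(=O)NC3(C(=O)NO)CC3)cc2)c2ccccc2n1`) differs from compound 2 by a group of 7 heavy atoms (4 carbon, 1 nitrogen, 2 oxygen; one three-membered non-aromatic ring of carbon only) in place of a group of 9 heavy atoms (5 carbon, 1 nitrogen, 3 oxygen; one four-membered non-aromatic ring with 1 hetero atom), on a sulfonamide nitrogen and keeps the shared core. For the measured compounds named here, the only measured step on that sulfonamide nitrogen is the large 21-fold lower number from compound 1 to compound 2 (1.31 log units; beyond the scatter) and it started from a group with no ring, so it offers little guidance for a swap between two ringed groups. In this assay no step beyond the scatter is therefore expected, and the estimated step is a 1.3-fold lower number from compound 2 to compound 3 (0.12 log units; within the scatter) with wide uncertainty. For compound 3 the estimated value is 150000 nM (range 30000 nM to 800000 nM).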

Compound 3, solubility: 46000000 nM
Beside the measured number, compound 3's estimate is 310-fold (2.49 log units) below it, outside the stated range (above it).
By their numbers in this assay, from the lowest: compound 2; then compound 1; then compound 3.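

In this assay exchanging one ringed group for another on a sulfonamide nitrogen gives a 230-fold higher number from compound 2 to compound 3 (2.36 log units; beyond the scatter) so this position remains highly sensitive even when both groups carry a ring. A ring alone does not set the direction, since an 11-fold higher number from compound 1 to compound 3 (1.05 log units; beyond the scatter) stands against a 21-fold lower number from compound 1 to compound 2 (1.31 log units; beyond the scatter) on the same nitrogen. Nothing measured here gives a reason for these steps.

The four-membered ring holds a hetero atom and the three-membered ring holds carbon only, so ring size and ring content remain tangled. From the compounds shown here alone, what a cyclobutane ring, a four-membered ring of carbon only, would give on this nitrogen stays open.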